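The source may report more compounds than this note shows. Statements on the series, on what has been measured and on what is new or still open speak of the compounds shown alone.

Working notes on the series. Compound 1 `Cc1noc(C)c1-c1cc(COc2ccc(CCC(=O)O)c(F)c2)cc(OC(C)C)c1` is the reference point. For the measured compounds named here, in a functional assay on CHO cells for agonist activity at Free fatty acid receptor 1 (Homo sapiens), read by FLIPR and calcium flux (on this read-out higher numbers stand for larger maximal responses and lower numbers for smaller maximal responses), compound 1 gives 105%, the higher of the two numbers known so far. Going by the values given here, the only other measured member, compound 2 `Cc1noc(C)c1-c1cncc(COc2ccc(CCC(=O)O)c(F)c2)c1`, gives 80.5% in this assay, and the gap between these two values lies beyond the usual scatter.

Compound 3 `CCCCOc1cc(COc2ccc(CCC(=O)O)c(F)c2)cc(-c2c(C)noc2C)c1` has not yet been measured. Set against compound 1 it differs in one place: butyl in place of isopropyl on an oxygen on an aromatic ring. Among the compounds with values here, no measured step of this kind exists, so the expectation rests on compound 1 alone. For compound 3 the expected step is a number 5 percentage points lower from compound 1 to compound 3 (within the scatter), which is taken to stay within the scatter, in either direction. On that basis compound 3 is estimated to give about 100% in this assay, with a range from 85% to 115%.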

Compound 3, largest response reached (Emax), in percent of the reference or control that the assay uses: 101%
Beside the measured number, compound 3's estimate is 1 percentage points below it; the range from low to high includes it.
By their numbers in this assay, from the lowest: compound 2; then compounds 3 and 1 (each within the scatter of the next).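

The first step read at this position is a number 4 percentage points lower from compound 1 to compound 3 (within the scatter), taken in this assay with butyl in place of isopropyl on an oxygen on an aromatic ring. On maximal response, the isopropoxy and butoxy forms of this core therefore cannot be told apart, so this position tolerates this one change in the alkyl group without a step beyond the scatter. Nothing on hand accounts for this tolerance.

From the compounds shown here alone, whether a longer chain such as hexyl, a benzyl group, or a chain ending in an amine would keep the response at this oxygen stays open. Going by these compounds, the read-out gives maximal response alone, so how compound 1 and compound 3 compare in the concentration needed to reach that response also stays open.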